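Swapping a para ester for a methyl on a triazene

This account rests on a few compounds, and the source may have more. Where it says the series, first, only, none or still open, it means among the compounds named here.

Compound 1 `CCOC(=O)c1ccc(/N=N/N(C)C(=O)[C@H](C)NC(C)=O)cc1`: 15.7 h
Compound 2 `CC(=O)N[C@H](C(=O)N(C)/N=N/c1ccc(C#N)cc1)C(C)C`: 84.3 h
Compound 3 `CCCC(=O)N[C@@H](C)C(=O)N(C)/N=N/c1ccc(C#N)cc1`: 9.1 h

Three compounds have been run in a physicochemical assay for metabolic stability, read by HPLC, in phosphate buffer, at pH 7.7; on this read-out lower numbers stand for a shorter-lived compound and higher numbers for a longer-lived compound. Compound 1 stands second highest of the three: its number and that of compound 3 lie within the scatter of each other, while compound 2 sits beyond the scatter above it.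

Compound 4 `CC(=O)N[C@@H](C)C(=O)N(C)/N=N/c1ccc(C)cc1` differs from compound 1 in one place: methyl in place of ethoxycarbonyl on an aromatic carbon, para to a large group. Going by the values given here, no measured pair shows this change, so its effect is unknown. A step in this assay of modest size, in either direction, is expected here, which is a 1.3-fold higher number from compound 1 to compound 4 (0.11 log units; within the scatter). Compound 4 is therefore estimated at 20 h, within a range from 7 h to 60 h.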

Compound 4, half-life: 46.5 h
For compound 4 the middle estimate is 2.3-fold (0.37 log units) below the measured one; the measured number falls inside the stated range.
By their numbers in this assay, from the lowest: compounds 3 and 1 (each within the scatter of the next); then compounds 4 and 2 (each within the scatter of the next).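

In this assay, methyl in place of ethoxycarbonyl on this aromatic carbon, para to a large group, gives a 3.0-fold higher number from compound 1 to compound 4 (0.47 log units; beyond the scatter), a step beyond the scatter. Going by these compounds alone, this is the first single change that can be read on its own, and it shows that the group at this position can shift the half-life. Nothing here explains the step.

This single step cannot show how the number would follow other groups at this position. On these data alone, how a carboxylic acid, an amine or a longer chain would compare on this carbon remains open.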